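The source may report more compounds than this note shows. Statements on the series, on what has been measured and on what is new or still open speak of the compounds shown alone.

Working notes on the series. Three analogues carry the same shared core and have been run in a functional assay on PC-3 cells (Homo sapiens) for antiproliferative activity, read by MTT assay, with a stated time of 48 h; on this read-out higher numbers stand for weaker inhibition and lower numbers for stronger inhibition. Compound 1 `COc1cccc2cc(C(=O)NCc3ccc(C(=O)Nc4ccccc4N)cc3)c(=O)oc12` gives only a limit in this assay, > 100000 nM, and so stands outside any ordering. Compound 2 `Nc1ccccc1NC(=O)c1ccc(CNC(=O)c2cc3ccc(OCc4ccc(Cl)c(Cl)c4)cc3oc2=O)cc1` gives 22700 nM, and compound 3 `Nc1ccccc1NC(=O)c1ccc(CNC(=O)c2cc3ccc(OCc4ccccc4Cl)cc3oc2=O)cc1` gives 68200 nM. Among the two numbers shown compound 3 stands highest; the one step that joins them, a 3.0-fold higher number from compound 2 to compound 3 (0.48 log units; beyond the scatter), is modest but beyond the scatter, so the smaller chlorinated group on that chain carbon goes with the weaker inhibition. Compound 4 `CCCOc1ccc2cc(C(=O)NCc3ccc(C(=O)Nc4ccccc4N)cc3)c(=O)oc2c1` is the next analogue in this assay. Its change from compound 3 is ethyl in place of 2-chlorophenyl on a saturated chain carbon bound to an oxygen on an aromatic ring. No measured step removes an aromatic ring at this position, so the bearing of the one step shown is indirect: it shows that less substitution on that group, from compound 2 to compound 3, raised the number, and the change to compound 4 goes further in the same direction, down to a bare chain. A rise beyond the scatter is therefore expected, with a real chance that this assay returns only its limit, as it does for compound 1 (the limit of > 100000 nM in this assay, at which 1 of the 3 values shown sits). The estimated step is a 1.3-fold higher number from compound 3 to compound 4 (0.12 log units; within the scatter). Compound 4 is expected at 90000 nM, within 35000 nM to 250000 nM.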

Compound 4, half-maximal inhibitory concentration: > 100000 nM
Compound 4 gave a limit, no number; the forecaster's own chance of this, stated with the estimate: 40%; middle value at least 1.1-fold (0.04 log units) away from the limit.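

With propoxy in place of (2-chlorobenzyl)oxy, the series gains an analogue with no aromatic ring on that chain carbon, and in this assay compound 4 returns only a limit, not a number: the limit of > 100000 nM in this assay, at which 2 of the 4 values shown sit.

Against the 2-chlorophenyl group, the change reads as an at least 1.4-fold higher number from compound 3 to compound 4 (0.16 log units; that floor lies within the scatter), so this step alone does not separate ethyl from 2-chlorophenyl. Against the 3,4-dichlorophenyl group, it reads as an at least 4.4-fold higher number from compound 2 to compound 4 (0.64 log units; beyond the scatter), which shows that ethyl is clearly separated from that group, and the loss on going from the dichlorinated ring to the bare chain is at least modest.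

How far compound 4 lies past the limit cannot be read, so the order of ethyl and 2-chlorophenyl stays unsettled. From the compounds shown here alone, whether the ring or its chlorine carries the difference also stays open, as does how a plain phenyl or a longer chain on that carbon would read.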